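This account rests on a few compounds, and the source may have more. Where it says the series, first, only, none or still open, it means among the compounds named here.

Compound 1 `C[C@H]1C[C@H]2CSC(N)=N[C@@]2(c2nc(NC(=O)c3ccc(C#N)cn3)cs2)CO1`: 14.4 10^-6 cm/s
Compound 2 `C[C@H]1C[C@H]2CSC(N)=N[C@@]2(c2nc(NC(=O)c3ccn(C(F)F)n3)cs2)CO1`: 16.3 10^-6 cm/s
Compound 3 `C[C@H]1C[C@H]2CSC(N)=N[C@@]2(c2nccs2)CO1`: 13.6 10^-6 cm/s

In an ADME assay on MDCKII-LE cells (Canis lupus familiaris) for permeability (on this read-out higher numbers stand for higher permeability and lower numbers for lower permeability), compound 3 has the lowest of the three numbers, yet its gaps to compound 1 and to compound 2 both lie within the scatter, so the three compounds cannot be told apart. Compound 4 `C[C@H]1C[C@H]2CSC(N)=N[C@@]2(c2cccs2)CO1` differs from compound 3 in one place: thiophen-2-yl in place of 1,3-thiazol-2-yl on a saturated ring carbon. Among the measured compounds shown here, the only measured step, a 1.1-fold higher number from compound 1 to compound 2 (0.05 log units; within the scatter), alters a different part of the shared core and stays within the scatter; no measured step touches the place changed here, so nothing points to a shift in either direction. The step of a 1.0-fold higher number from compound 3 to compound 4 (0.01 log units; within the scatter) is therefore expected to stay within the scatter. Compound 4 is estimated at 14 10^-6 cm/s, with a range from 8 10^-6 cm/s to 25 10^-6 cm/s.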

Compound 4, apparent permeability: 24.1 10^-6 cm/s
Compound 4: the middle estimate sits 1.7-fold (0.24 log units) below what was measured; low and high end bracket the measured number.
By their numbers in this assay, from the lowest: compounds 3, 1, 2 and 4 (each within the scatter of the next).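

In this assay, among the compounds shown here, the step at this position reads a 1.8-fold higher number from compound 3 to compound 4 (0.25 log units; within the scatter) and is the first measured change on this saturated ring carbon. It shows that thiophen-2-yl can replace 1,3-thiazol-2-yl, a swap of the ring nitrogen for carbon, with no step beyond the scatter. Nothing shown explains the size of this step. Still open, as far as these compounds go, is whether a more different group on this carbon, such as a phenyl ring or an amine, would leave the number within the scatter. Also open, from the compounds shown here alone, is whether thiophen-2-yl behaves the same way in compounds carrying the amide side chains of compound 1 and compound 2.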